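The source may hold more compounds than are shown below. What is called first, only, known or untested is meant among the compounds shown, and "the series" means these compounds.

Measured compounds in a functional assay (aorta) with Oryctolagus cuniculus as the target; on this read-out higher numbers stand for weaker inhibition and lower numbers for stronger inhibition:
compound 1 `CCO/C(O)=C1\C(C)=NC(C)=C(C(=O)OCCCN2C(=O)c3ccccc3S2(=O)=O)C1c1cccc([N+](=O)[O-])c1` — 1.9 nM
compound 2 `COCCO/C(O)=C1\C(C)=NC(C)=C(C(=O)OCCCN2C(=O)c3ccccc3S2(=O)=O)C1c1cccc([N+](=O)[O-])c1` — 6.8 nM
compound 3 `CCO/C(O)=C1\C(C)=NC(C)=C(C(=O)OCCCN2C(=O)c3ccccc3S2(=O)=O)C1c1ccccc1[N+](=O)[O-]` — 2.6 nM

Compound 3 gives the second highest of the three numbers in this assay. Its nearest neighbour is compound 1, and that gap, a 1.4-fold higher number from compound 1 to compound 3 (0.14 log units; within the scatter), lies within the scatter; the furthest is compound 2, whose number is higher still. Compound 4 `CC1=NC(C)=C(C(=O)OCCCN2C(=O)c3ccccc3S2(=O)=O)C(c2ccccc2[N+](=O)[O-])/C1=C(\O)OCC1CCCO1` has not yet been measured. It differs from compound 3 in one place: oxolan-2-yl in place of methyl on a saturated chain carbon bound to an oxygen on an unsaturated carbon.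

Among the compounds with values here, the only measured step that bears on this change is the one from compound 1 to compound 2, where a methoxy was added on the same ester-side chain, two bonds along from the oxygen: a 3.6-fold higher number from compound 1 to compound 2 (0.55 log units; beyond the scatter). That step was modest but beyond the scatter, and it moved the number upward. The change to compound 4 also adds an oxygen-bearing group on that chain, here a ring, so a step of similar size and in the same direction is expected in this assay, namely a 2.3-fold higher number from compound 3 to compound 4 (0.36 log units; beyond the scatter). On that basis compound 4 is estimated at 6 nM, with a range from 2.5 nM to 15 nM.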

Compound 4, half-maximal inhibitory concentration: 6.8 nM
For compound 4 the middle estimate is 1.1-fold (0.05 log units) below the measured one, and the stated range covers the measured number.
By their numbers in this assay, from the lowest: compounds 1 and 3 (each within the scatter of the next); then compounds 2 and 4 (each within the scatter of the next).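

In this assay, oxolan-2-yl in place of methyl on the saturated chain carbon bound to an oxygen on an unsaturated carbon gives a 2.6-fold higher number from compound 3 to compound 4 (0.42 log units; beyond the scatter), so this position does not tolerate the change without a shift beyond the scatter. The earlier methoxy step, a 3.6-fold higher number from compound 1 to compound 2 (0.55 log units; beyond the scatter), came from an open chain on the 3-nitrophenyl compounds, whereas this step comes from a ring on the 2-nitrophenyl compounds, so the upward move on extending the ethoxy group now holds for both extensions and both nitrophenyl series shown, and no compound here goes against it. Nothing among the data shown accounts for this rise.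

The compounds shown leave open whether the ring oxygen plays any part in the step, since the comparison that would separate the ring from its oxygen, a cyclopentylmethyl group or a plain propyl chain at this place, lies outside them. They also leave open how an amine or a carboxylic acid on this chain would read, and what (oxolan-2-yl)methoxy would give alongside the 3-nitrophenyl group.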